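Permeability notes: biaryl in place of a benzyl group

This account rests on a few compounds, and the source may have more. Where it says the series, first, only, none or still open, it means among the compounds named here.

Compound 2 `Fc1ccc(Cc2ccc3c(NCCCNCc4ccco4)ccnc3c2)cc1` gives 23 10^-6 cm/s in an ADME assay for permeability, using PAMPA, with a stated time of 30 min, at pH 7.4; on this read-out lower numbers stand for lower permeability and higher numbers for higher permeability. Compound 1 `CC(C)Cc1ccc2c(NCCCNCc3ccco3)ccnc2c1` gives 23 10^-6 cm/s in this assay; the step of no change at the digits printed from compound 1 to compound 2 (within the scatter), 4-fluorophenyl in place of isopropyl on a saturated chain carbon bound to an aromatic carbon, left the read-out where it was. Compound 3 `COc1ccc(-c2ccc3c(NCCCNCc4ccco4)ccnc3c2)cc1` carries 4-methoxyphenyl in place of 4-fluorobenzyl on an aromatic carbon. Among the measured compounds shown here, only that one measured step bears on the change, and it was flat; again an aromatic group leaves and an aromatic group enters, now directly on the ring. Compound 3 is therefore expected near 20 10^-6 cm/s in this assay, range 10 10^-6 cm/s to 40 10^-6 cm/s, a step of a 1.2-fold lower number from compound 2 to compound 3 (0.06 log units; within the scatter) not beyond the scatter.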

Compound 3, apparent permeability: 237 10^-6 cm/s
Estimate against measurement, compound 3: 12-fold (1.07 log units) below, outside the stated range (above it).
By their numbers in this assay, from the lowest: compounds 1 and 2 (each within the scatter of the next); then compound 3.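

In this assay this position is not indifferent to what it carries: the number moves a 10-fold higher number from compound 2 to compound 3 (1.01 log units; beyond the scatter) with 4-methoxyphenyl in place of 4-fluorobenzyl, and a 10-fold higher number from compound 1 to compound 3 (1.01 log units; beyond the scatter) with 4-methoxyphenyl in place of isobutyl. The flat earlier step exchanged groups that both reach the aromatic carbon through a saturated carbon, whereas here the new aromatic ring sits directly on that carbon and brings a methoxy group, so two features change together. Which feature carries the step stays open, and a plain phenyl or a 4-methoxybenzyl group at this carbon would separate them. No measurement shown accounts for the size of the step.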